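This account rests on a few compounds, and the source may have more. Where it says the series, first, only, none or still open, it means among the compounds named here.

Compound 1 `CCC(C)(C)Cc1c[nH]c(CCc2ccc(-n3ncnn3)cc2)n1` gives 89 nM in a functional assay on HEK293 cells for agonist activity at Bombesin receptor subtype-3 (Homo sapiens), read by luminescence and calcium flux, with a stated time of 10 min; a higher number here means that more compound is needed for the effect, a lower number that less compound is needed.
Compound 2 `CCC(C)(C)Cc1c[nH]c(CCc2ccc(-c3ccccc3C(=O)O)cc2)n1` gives 101 nM in this assay.

Among the two measured compounds, compound 1 has the lowest number, and its nearest neighbour is compound 2, the step being a 1.1-fold higher number from compound 1 to compound 2 (0.05 log units; within the scatter). Compound 3 `CCC(C)(C)Cc1c[nH]c(CCc2ccc(-c3csnn3)cc2)n1` is not yet measured. It differs from compound 1 in one place: 1,2,3-thiadiazol-4-yl in place of 2H-tetrazol-2-yl on an aromatic carbon. Among the compounds with values here, the only measured step that bears on this change is the one from compound 1 to compound 2, where a different group took the same position on the same ring; that step was a 1.1-fold higher number from compound 1 to compound 2 (0.05 log units; within the scatter), which lies within the scatter. With so small a precedent, the expectation is that the new ring will also leave the number roughly where it stands, with no step beyond the scatter. Compound 3 is therefore estimated at 110 nM, with a range from 40 nM to 320 nM, an expected step of a 1.2-fold higher number from compound 1 to compound 3 (0.09 log units; within the scatter).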

Compound 3, half-maximal effective concentration: 104 nM
Compound 3: the middle estimate sits 1.1-fold (0.02 log units) above what was measured; low and high end bracket the measured number.
By their numbers in this assay, from the lowest: compounds 1, 2 and 3 (each within the scatter of the next).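

Swapping 2H-tetrazol-2-yl for 1,2,3-thiadiazol-4-yl keeps a five-membered aromatic ring at this place but brings in sulfur and fewer hydrogen-bond acceptors, and in this assay the result is a 1.2-fold higher number from compound 1 to compound 3 (0.07 log units; within the scatter). The same ring set against the 2-carboxyphenyl group gives a 1.0-fold higher number from compound 2 to compound 3 (0.01 log units; within the scatter), so three quite different rings at this place now sit within the scatter of one another, and the carboxylic acid of compound 2 is not needed to match it. Nothing measured here explains why these groups give such similar numbers.

Going by these compounds, all three compounds carry a ring at this place, so it remains open whether a small methyl group, an amine or a plain hydrogen would hold the number as well. On these data alone, whether any group here can move it beyond the scatter also remains open.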